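A few compounds are considered here, and "the series" means these few. Any claim that something is new, unique, unknown or untested is made for them only; others in the source may bear on it.

Compound 1 `CCC(C)(C)Cc1c[nH]c(CCc2ccc(-c3ccncc3)cc2)n1` and compound 2 `CCC(C)(C)Cc1c[nH]c(CCc2ccc(-c3cnccn3)cc2)n1` share one core and differ only in the aromatic ring that hangs from the phenyl group. In a functional assay on HEK293 cells for agonist activity at Bombesin receptor subtype-3 (Mus musculus), read by luminescence and calcium flux, with a stated time of 10 min (on this read-out higher numbers stand for an effect only at larger amounts of compound and lower numbers for an effect already at smaller amounts), compound 1 gives 15 nM, the highest of the two numbers recorded, while compound 2 gives 11 nM. For the measured compounds named here, the single measured step, a 1.4-fold lower number from compound 1 to compound 2 (0.13 log units; within the scatter), shows that exchanging one six-membered heteroaromatic ring for another leaves the read-out essentially unchanged. Compound 3 `CCC(C)(C)Cc1c[nH]c(CCc2ccc(-c3cccc(C#N)n3)cc2)n1` carries a further variation at the same position: 6-cyanopyridin-2-yl in place of pyridin-4-yl on an aromatic carbon. Going by the values given here, no measured step covers a nitrile on that ring, so the step from compound 1 to compound 2 is the only guide, and it suggests that ring exchanges here are tolerated without a shift beyond the scatter. On that basis compound 3 is expected to show a step of a 1.3-fold higher number from compound 1 to compound 3 (0.12 log units; within the scatter), nothing beyond the scatter. Compound 3 is therefore estimated at 20 nM in this assay, with a range from 6 nM to 70 nM.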

Compound 3, half-maximal effective concentration: 26 nM
Estimate against measurement, compound 3: 1.3-fold (0.11 log units) below; measured number inside the range.
By their numbers in this assay, from the lowest: compounds 2, 1 and 3 (each within the scatter of the next, the first and the last beyond it).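

Set against the pyrazin-2-yl ring of compound 2, the 6-cyanopyridin-2-yl group gives the first step at this position that passes the scatter, and it is a modest one (a 2.4-fold higher number from compound 2 to compound 3 (0.37 log units; beyond the scatter)). Against the pyridin-4-yl ring of compound 1, the same group stays within the scatter (a 1.7-fold higher number from compound 1 to compound 3 (0.24 log units; within the scatter)), so in this assay this position accommodates a ring bearing a nitrile with little change in the read-out. No measurement available here accounts for the difference between these two steps.

The compounds shown leave open what a plain pyridin-2-yl ring would give, and so how much of the result belongs to the nitrile and how much to the ring itself. They also leave open how an amine or a carboxylic acid on that ring would read.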